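A few compounds are considered here, and "the series" means these few. Any claim that something is new, unique, unknown or untested is made for them only; others in the source may bear on it.

Measured so far in a physicochemical assay for acid dissociation:
compound 1, `CC(C)(C)c1ccc(Oc2ccc3c(NCCCNCc4ccco4)ccnc3c2)cc1`, gives 9.28
compound 2, `COc1ccc(F)cc1CNCCCNc1ccnc2cc(Oc3ccc(C(C)(C)C)cc3)ccc12`, gives 9.28

Compound 1 stands level with compound 2 at the digits shown; these are the only two measured compounds, and the step from one to the other, no change at the digits printed from compound 1 to compound 2 (within the scatter), swaps 5-fluoro-2-methoxyphenyl for furan-2-yl on a saturated chain carbon bound to an amine nitrogen without moving the read-out beyond the scatter.

Compound 3, `COc1ccc(Oc2ccc3c(NCCCNCc4ccco4)ccnc3c2)cc1`, has not yet been measured. It differs from compound 1 as follows: methoxy in place of tert-butyl on an aromatic carbon. The change sits on an aromatic carbon of a six-membered aromatic ring of carbon only, para to a large group, at the far end of the molecule from the chain that was altered between compound 1 and compound 2. Within the data shown here, no measured step touches this ring, so the only guide is that the one measured change elsewhere in the molecule left this assay unmoved. Compound 3 is therefore expected to stand close to compound 1, with a step of a number 0.03 log units lower from compound 1 to compound 3 (within the scatter), giving an estimated 9.25, between 8.95 and 9.55.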

Compound 3, acid dissociation constant: 9.28
Estimate against measurement, compound 3: 0.03 log units below, within the range that was stated.
By their numbers in this assay, from the lowest: compounds 1, 2 and 3 (each within the scatter of the next).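

In this assay, among these compounds, the swap of tert-butyl for methoxy on an aromatic carbon of a six-membered aromatic ring of carbon only, para to a large group, gives no change at the digits printed from compound 1 to compound 3 (within the scatter), the first reading for a change at this position. The change from 4-(tert-butyl)phenyl to 4-methoxyphenyl replaces a group of 4 heavy atoms and 0 hydrogen-bond acceptors with one of 2 heavy atoms and 1 hydrogen-bond acceptor, yet it leaves the read-out as level as the earlier chain change did, no change at the digits printed from compound 1 to compound 2 (within the scatter), so a change in either of two separate places has now been seen to leave this assay unmoved within the scatter. Nothing available accounts for this lack of movement at either place.

The compounds shown leave open whether an amine or a carboxylic acid at this same position on the ring would also leave the read-out level, and whether a longer chain in the part of the molecule carrying the furan-2-yl group would do so. They also leave open whether methoxy and 5-fluoro-2-methoxyphenyl, taken together in one compound, would stand level with compound 1.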